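Swapping the aryl group on a thiazole acetic acid antagonist

A few compounds are considered here, and "the series" means these few. Any claim that something is new, unique, unknown or untested is made for them only; others in the source may bear on it.

Of the compounds shown here, three sharing one core have been measured in an in vitro functional assay on HEK285-7 cells for antagonist activity at prostaglandin D2 receptor 2 (Homo sapiens), read by BRET and beta-arrestin recruitment; on this read-out lower numbers stand for stronger inhibition and higher numbers for weaker inhibition. Compound 1 `N#Cc1cc(-c2nc(C(c3ccc(F)cc3)c3ccc(F)cc3)sc2CC(=O)O)ccc1F` gives 520 nM, which is the second highest of the three numbers. Compound 2 `O=C(O)Cc1sc(C(c2ccccc2)c2ccccc2)nc1-c1ccc(F)c(F)c1` gives 43 nM, a far lower number and therefore much stronger inhibition; compound 3 `O=C(O)Cc1sc(C2COc3ccccc3O2)nc1-c1ccc(Cl)cc1` gives 2000 nM, the highest number of the set. Compound 1 thus sits closer to compound 3 than to compound 2, and both gaps are beyond the usual scatter. As these three differ from one another in more than one place, none of the gaps can be tied to a single structural change.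

Compound 4 `CS(=O)(=O)Nc1cccc(-c2nc(C(c3ccc(F)cc3)c3ccc(F)cc3)sc2CC(=O)O)c1` has not yet been measured. It differs from compound 1 in one place: 3-(methanesulfonamido)phenyl in place of 3-cyano-4-fluorophenyl on an aromatic carbon. A sulfonamide bearing a hydrogen-bond donor replaces a nitrile and a fluorine on the same ring. Among the measured compounds shown here, nothing among the measured compounds isolates this kind of exchange, so the direction of the step is uncertain. The estimated change a 1.5-fold lower number from compound 1 to compound 4 (0.17 log units; within the scatter) is expected to stay within the usual scatter of repeated measurements. Compound 4 is expected to give 350 nM, with a plausible range from 90 nM to 1400 nM.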

Compound 4, half-maximal inhibitory concentration: 370 nM
Beside the measured number, compound 4's estimate is 1.1-fold (0.02 log units) below it; the measured number falls inside the stated range.
By their numbers in this assay, from the lowest: compound 2; then compounds 4 and 1 (each within the scatter of the next); then compound 3.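

In this assay, among the compounds shown here, putting 3-(methanesulfonamido)phenyl in place of 3-cyano-4-fluorophenyl gives a 1.4-fold lower number from compound 1 to compound 4 (0.15 log units; within the scatter), the first exchange in this set that can be read at a single place. The two compounds cannot be told apart at this aromatic carbon, next to the ring nitrogen and next to the ring atom that bears a carboxymethyl group, even though the entering group has 11 heavy atoms against 9, and 1 hydrogen-bond donor where the leaving group has 0. Nothing available here accounts for the two groups reading alike.

On these data alone, the nitrile and the fluorine leave together in this exchange, so their separate contributions stay unknown, and a 3-cyanophenyl or a 4-fluorophenyl group on the core of compound 1 would be needed to pull them apart. As far as these compounds go, it also remains open whether this position would read the same with a different kind of group on the phenyl ring, such as an amine or a carboxylic acid, or with the methanesulfonamido group moved to another ring carbon.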